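Series notes: N-benzyl anilides, hydroxyphenyl to bromomethoxyphenyl swap

The compounds below may be only part of what the source reports. "The series", "measured", "known", "first", "only" and "open" are said of these compounds alone.

Measured compounds:
compound 1, `C/C=C/C(=O)N(Cc1cccc(O)c1)c1cc(OC)c(OC)c(OC)c1`, 14700 nM
compound 2, `CCC(=O)N(Cc1ccc(OC)c(O)c1)c1cc(OC)c(OC)c(OC)c1`, 98 nM
compound 3, `C/C=C/C(=O)N(Cc1cc(OC)c(OC)c(OC)c1)c1ccc(OC)c(O)c1`, 9160 nM

All three values come from a functional assay on KYSE-450 cells (Homo sapiens) for inhibition, read by MTT assay, with a stated time of 48 h; a higher number here means a weaker inhibitor, a lower number a stronger inhibitor. Compound 1 gives the highest number of the three. Compound 3 sits close to it, and the gap between compound 1 and compound 3 lies within the scatter, so no order between them can be read. Compound 2 stands far apart: its number is lower than that of compound 1 by a margin well beyond the scatter, so compound 2 is the strongest inhibitor among the measured set.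

Compound 4, `C/C=C/C(=O)N(Cc1ccc(OC)c(Br)c1)c1cc(OC)c(OC)c(OC)c1`, has not been measured. It differs from compound 1 in one place: 3-bromo-4-methoxyphenyl in place of 3-hydroxyphenyl on a saturated chain carbon bound to an amide-type nitrogen. Among the compounds with values here, no directly comparable pair of measured compounds shows this exchange, so the size of the step cannot be taken from the data. The amide portion of compound 4 matches that of compound 1 and compound 3, both of which give high numbers, whereas the low number of compound 2 comes with a different amide and a different benzyl substitution.

The step from compound 1 to compound 4 is expected to be a modest lowering, a 2.9-fold lower number from compound 1 to compound 4 (0.47 log units; beyond the scatter), with wide uncertainty. For compound 4 in this assay the estimate is 5000 nM, with a range from 800 nM to 30000 nM.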

Compound 4, half-maximal inhibitory concentration: 10500 nM
Compound 4: middle estimate off by 2.1-fold (0.32 log units), on the low side; the range from low to high includes it.
By their numbers in this assay, from the lowest: compound 2; then compounds 3, 4 and 1 (each within the scatter of the next).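

In this assay, 3-bromo-4-methoxyphenyl in place of 3-hydroxyphenyl on a saturated chain carbon bound to an amide-type nitrogen gives a 1.4-fold lower number from compound 1 to compound 4 (0.15 log units; within the scatter) and so produces no readable shift. With the amide of compound 1, this position therefore accepts the larger group, which has no hydrogen-bond donor, with no readable change in the number. No supporting data bear on why the number holds here.

The exchange removes the hydroxyl and adds bromine and methoxy together, so the compounds shown do not separate the contribution of each part. As far as these compounds go, what a 3-aminophenyl or 3-carboxyphenyl group would give at this position remains open, as does whether 3-bromo-4-methoxyphenyl would give the same result with a different amide.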